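The source may report more compounds than this note shows. Statements on the series, on what has been measured and on what is new or still open speak of the compounds shown alone.

Working notes on the fluorinated bicyclic amino diacid series.

Three compounds have numbers in an assay on CHO cells for binding affinity to metabotropic glutamate receptor 2 (Rattus norvegicus); a lower number here means a stronger inhibitor, a higher number a weaker inhibitor. Compound 1 `CCC(C)O[C@@H]1C[C@@H]2[C@H]([C@]1(N)C(=O)O)[C@@]2(F)C(=O)O` carries a saturated alkoxy group on the core and gives 6.68 nM. Compound 2 `N[C@]1(C(=O)O)[C@H]2[C@@H](C[C@H]1OCc1cccc(Br)c1)[C@]2(F)C(=O)O` carries a 3-bromophenyl on a saturated chain carbon bound to an oxygen on a saturated carbon and gives 4.71 nM. Compound 3 `N[C@]1(C(=O)O)[C@H]2[C@@H](C[C@H]1OCc1ccccc1-c1ccccc1)[C@]2(F)C(=O)O` carries a biphenyl variant at the same place and gives 4.07 nM. Compound 2 has the second highest of the three numbers; its gap to compound 3 and its gap to compound 1 both lie within the scatter, so no order can be read among these three.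

Compound 4 `N[C@]1(C(=O)O)[C@H]2[C@@H](C[C@H]1OCc1c(Cl)cccc1Cl)[C@]2(F)C(=O)O` has not been measured. Relative to compound 2 the difference is 2,6-dichlorophenyl in place of 3-bromophenyl on a saturated chain carbon bound to an oxygen on a saturated carbon. Among the compounds with values here, no step between measured compounds isolates such a change, so the expectation rests on the three values alone, which sit close together across rather different groups at this place.

Compound 4 is expected to land near compound 2, with a step of a 1.1-fold higher number from compound 2 to compound 4 (0.03 log units; within the scatter) that should stay within the scatter in either direction. The estimate for compound 4 in this assay is 5 nM, with a range from 2 nM to 12.5 nM.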

Compound 4, inhibition constant: 4.3 nM
Compound 4: middle estimate off by 1.2-fold (0.07 log units), on the high side, and the stated range covers the measured number.
By their numbers in this assay, from the lowest: compounds 3, 4, 2 and 1 (each within the scatter of the next).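

Within the data shown here, replacing 3-bromophenyl with 2,6-dichlorophenyl on a saturated chain carbon bound to an oxygen on a saturated carbon gives a 1.1-fold lower number from compound 2 to compound 4 (0.04 log units; within the scatter) in this assay, and this is the first step that can be read for one change alone. The two groups cannot be told apart in this read-out, so a phenyl with two chlorines and a phenyl with one bromine sit within the scatter of each other at this place, where earlier only comparisons of much less closely related groups were available. No measurement at hand gives a reason for this closeness.

The compounds shown leave open whether the numbers stay this close with groups of another kind at this place, such as a phenyl carrying an amine or a carboxylic acid, or a longer chain in place of the single saturated chain carbon. They also leave open whether a single chlorine, as in 2-chlorophenyl, would read the same as the 2,6-dichlorophenyl of compound 4.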